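The source may report more compounds than this note shows. Statements on the series, on what has been measured and on what is new or still open speak of the compounds shown alone.

Two of the three compounds in this set carry a result in a functional assay on HaCaT cells (Homo sapiens), read by fluorescence and BrdU incorporation, with a stated time of 48 h, tested at 10 uM; a lower number here means a stronger effect, a higher number a weaker effect of the compound at the concentration tested. Compound 1 `COc1cc(O)c(C(=O)/C=C/c2ccc(F)cc2)c(OC)c1` is recorded simply as "not active" (no number reported), with no figure attached to it. Among the measured compounds shown here, compound 2 `COc1cc(OC)c(C(=O)/C=C/c2ccccc2SC)c(OC)c1` is the one member with an actual number: in this assay compound 2 gives 24%. For the measured compounds named here, that is the only value shown, so compound 2 cannot be placed above or below any other measured compound; it stands alone, with compound 1 beside it as an entry without a number. Compound 3 `COc1cccc(/C=C/C(=O)c2c(OC)cc(OC)cc2OC)c1` has not yet been measured. It differs from compound 2 in one place: 3-methoxyphenyl in place of 2-(methylsulfanyl)phenyl on a double-bonded chain carbon bound to a double-bonded chain carbon. Going by the values given here, no step between two measured compounds is available to calibrate what such an exchange does here, and compound 1 contributes only a report of inactivity. The exchange is expected to move the read-out toward a weaker effect by a number 16 percentage points higher from compound 2 to compound 3 (beyond the scatter), a modest shift that could still fall within the ordinary scatter. On that basis compound 3 is estimated to give 40% in this assay, with a range from 15% to 80%.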

Compound 3, a percentage reported as activity, at one concentration (the size of the read-out at that concentration, not a potency): 19%
Beside the measured number, compound 3's estimate is 21 percentage points above it; low and high end bracket the measured number.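

Among the compounds shown here, exchanging 2-(methylsulfanyl)phenyl for 3-methoxyphenyl on a double-bonded chain carbon bound to a double-bonded chain carbon gives in this assay the set's first step between two measured compounds, a change of a number 5 percentage points lower from compound 2 to compound 3 (within the scatter) and thus no separation between the pair. The earlier compounds shown here could not show this, since one number stood alone and the other entry had none; now two different substituted phenyl groups at this place give read-outs that cannot be told apart in this assay. The exchange replaces a sulfur-bearing group with an oxygen-bearing one of the same heavy-atom count and also alters the name-given substitution site on the ring, yet this single step cannot separate those two differences, and nothing shown explains why the values stay within the scatter.

Going by these compounds, it remains open whether 2-methoxyphenyl or 3-(methylsulfanyl)phenyl would read like these two, which would separate the atom exchanged from its place on the ring. On these data alone, it is also open whether an amine, a carboxylic acid or a longer chain on that ring would produce a step beyond the scatter.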